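Exchanging 1,3-benzothiazol-2-yl for 1,3-benzoxazol-2-yl on a sulfur

The compounds below may be only part of what the source reports. "The series", "measured", "known", "first", "only" and "open" are said of these compounds alone.

In a functional assay on PC-3 cells (Homo sapiens) for antiproliferative activity, read by MTT assay, with a stated time of 48 h (a lower number here means a stronger inhibitor, a higher number a weaker inhibitor), compound 1 (`COc1ccc(CN(C(=O)Cn2cc(COc3ccc4c(C)cc(=O)oc4c3)nn2)c2cc(OC)c(OC)c(OC)c2)cc1`) gives 340 nM while compound 2 (`COc1ccc(CN(C(=O)Cn2cc(COc3ccccc3)nn2)c2cc(OC)c(OC)c(OC)c2)cc1`) gives 45300 nM and compound 3 (`COc1ccc(CN(C(=O)Cn2cc(CSc3nc4ccccc4s3)nn2)c2cc(OC)c(OC)c(OC)c2)cc1`) gives 28500 nM as its reading. Compound 3 thus sits within the scatter of compound 2 and far from compound 1, on the side of higher numbers. Compound 4 (`COc1ccc(CN(C(=O)Cn2cc(CSc3nc4ccccc4o3)nn2)c2cc(OC)c(OC)c(OC)c2)cc1`) differs from compound 3 by one exchange (1,3-benzoxazol-2-yl in place of 1,3-benzothiazol-2-yl on a sulfur) that puts 1,3-benzoxazol-2-yl in place of 1,3-benzothiazol-2-yl on a sulfur. Within the data shown here, no measured step makes this exchange. The closest one brings in (1,3-benzothiazol-2-yl)sulfanyl in place of phenoxy (a 1.6-fold lower number from compound 2 to compound 3 (0.20 log units; within the scatter)) and stays within the scatter, while the large step (a 130-fold higher number from compound 1 to compound 2 (2.12 log units; beyond the scatter)) concerns a different group. No step beyond the scatter is therefore expected in this assay for this exchange. The estimate amounts to an expected 1.1-fold lower number from compound 3 to compound 4 (0.06 log units; within the scatter) and no more. For compound 4 the estimated value is 25000 nM with 8000 nM and 70000 nM as the expected ends of its range.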

Compound 4, half-maximal inhibitory concentration: 5050 nM
Compound 4: middle estimate off by 5.0-fold (0.69 log units), on the high side; measured number outside the range, below it.
By their numbers in this assay, from the lowest: compound 1; then compound 4; then compounds 3 and 2 (each within the scatter of the next).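

In this assay, the group on the sulfur proves sensitive to a single atom: 1,3-benzoxazol-2-yl in place of 1,3-benzothiazol-2-yl, with equal heavy-atom counts, gives a 5.6-fold lower number from compound 3 to compound 4 (0.75 log units; beyond the scatter) and moves the series beyond the scatter. Measured against phenoxy, where the benzothiazole group had stayed within the scatter, (1,3-benzoxazol-2-yl)sulfanyl gives a 9.0-fold lower number from compound 2 to compound 4 (0.95 log units; beyond the scatter) in the same assay. Nothing available here accounts for this difference.

As far as these compounds go, it remains open whether a 1H-benzimidazol-2-yl group on the sulfur would follow the benzoxazole or the benzothiazole. From the compounds shown here alone, the effect of an amine nitrogen in place of that sulfur also remains open.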